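Trifluorobutoxy in Place of Isopentyloxy on Compound 2

This account rests on a few compounds, and the source may have more. Where it says the series, first, only, none or still open, it means among the compounds named here.

Of the compounds shown here, three have so far been measured in an assay on cells for inhibition of phosphatidylcholine:ceramide cholinephosphotransferase 2 (Homo sapiens), read by mass spectrometry, with stated times of 60 min and 30 min; on this read-out higher numbers stand for weaker inhibition and lower numbers for stronger inhibition. Compound 1 `COc1cc(CN(C)C(=O)c2c(OCCCC3CCN(C(=O)OC(C)(C)C)CC3)c3ccccc3n(C)c2=O)cc(OC)c1` gives 91 nM, and compound 3 `COc1cc(CN(C)C(=O)c2c(OCCCC3CCN(C(=O)OC(C)(C)C)CC3)c3cccnc3n(C)c2=O)cc(OC)c1` gives 130 nM. Compound 2 `CC(C)CCOc1c(C(=O)N(C)Cc2cc(C(F)(F)F)cc(C(F)(F)F)c2)c(=O)n(C)c2ccccc12` gives 350 nM, the highest of the three numbers; its gaps to compound 3 and to compound 1 both lie beyond the scatter, so compound 2 shows the weakest inhibition of the set. Compound 4 `CN(Cc1cc(C(F)(F)F)cc(C(F)(F)F)c1)C(=O)c1c(OCCCC(F)(F)F)c2ccccc2n(C)c1=O` has not yet been measured. It differs from compound 2 in one place: 2,2,2-trifluoroethyl in place of isopropyl on a saturated chain carbon, two bonds along the chain from an oxygen on an aromatic ring. Among the measured compounds shown here, no measured pair shows this change, so the data point in neither direction. Compound 4 is therefore expected to stay within the scatter of compound 2, a step of a 1.1-fold lower number from compound 2 to compound 4 (0.04 log units; within the scatter). The estimate for compound 4 is 320 nM, with a range from 110 nM to 1000 nM.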

Compound 4, half-maximal inhibitory concentration: 120 nM
Compound 4: middle estimate off by 2.7-fold (0.43 log units), on the high side; low and high end bracket the measured number.
By their numbers in this assay, from the lowest: compounds 1, 4 and 3 (each within the scatter of the next); then compound 2.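

Among the compounds shown here, exchanging isopentyloxy for 4,4,4-trifluorobutoxy gives the first one-place comparison at this chain, and in this assay it brings a 2.9-fold lower number from compound 2 to compound 4 (0.46 log units; beyond the scatter) as a modest step beyond the scatter. This position therefore responds to 2,2,2-trifluoroethyl in place of isopropyl, and the change goes toward stronger inhibition. No measurement at hand explains the step.

Going by these compounds, it remains open whether the fluorine atoms or the unbranched chain carries the step, which a plain butoxy group would separate. On these data alone, how a longer chain or a terminal amine would read here also stays open.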